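This account rests on a few compounds, and the source may have more. Where it says the series, first, only, none or still open, it means among the compounds named here.

Three sulfonyl-hydroxyguanidine analogues on a shared core have been measured. Compound 1 `COc1cc(CSc2cc(Cl)c(-c3nnc(-c4ccccc4)s3)cc2S(=O)(=O)NC(=N)NO)cc(OC)c1OC` gives 3240 nM in a functional assay on UACC-62 cells (Homo sapiens) (on this read-out lower numbers stand for stronger inhibition of growth and higher numbers for weaker inhibition of growth), the highest of the three numbers recorded. Compound 2 `COc1cc(CSc2cc(Cl)c(-c3nc(-c4ccc(Cl)cc4)no3)cc2S(=O)(=O)NC(=N)NO)cc(OC)c1OC` gives 1950 nM in this assay, and compound 3 `N=C(NO)NS(=O)(=O)c1cc(-c2nnc(-c3ccc(Cl)cc3)s2)c(Cl)cc1SCc1ccccc1` gives 2020 nM; both sit within the usual scatter of the number for compound 1, so no order among the three can be drawn. Compound 4 `COc1cc(CSc2cc(Cl)c(-c3nnc(-c4ccc(Cl)cc4)s3)cc2S(=O)(=O)NC(=N)NO)cc(OC)c1OC` differs from compound 1 by chloro in place of hydrogen on an aromatic carbon. For the measured compounds named here, only one measured step bears on it: a 1.7-fold lower number from compound 1 to compound 2 (0.22 log units; within the scatter), which stayed within the scatter but also exchanged the five-membered heteroaromatic ring, so the share of the chloro alone cannot be separated. Compound 3 also carries the chloro but differs from compound 1 in a second place, and its number is likewise within the scatter of compound 1. On this evidence compound 4 is expected to show a 1.4-fold lower number from compound 1 to compound 4 (0.13 log units; within the scatter), a change not beyond the scatter. Compound 4 is therefore estimated at 2400 nM, with a range from 1200 nM to 4800 nM.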

Compound 4, concentration for 50% growth inhibition: 16200 nM
Compound 4: middle estimate off by 6.8-fold (0.83 log units), on the low side; measured number above the stated range.
By their numbers in this assay, from the lowest: compounds 2, 3 and 1 (each within the scatter of the next); then compound 4.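

In this assay, for the compounds shown here, the change from phenyl to 4-chlorophenyl gives a 5.0-fold higher number from compound 1 to compound 4 (0.70 log units; beyond the scatter) and so moves the number beyond the scatter, which none of the earlier comparisons had done. The other two single changes that lead to compound 4 point the same way, with an 8.0-fold higher number from compound 3 to compound 4 (0.90 log units; beyond the scatter) for 3,4,5-trimethoxyphenyl in place of phenyl and an 8.3-fold higher number from compound 2 to compound 4 (0.92 log units; beyond the scatter) for the exchange of the five-membered heteroaromatic group, so among these four compounds the higher number appears only where 4-chlorophenyl, the thiadiazolyl group and 3,4,5-trimethoxyphenyl occur together. Nothing shown here accounts for this rise.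

The compounds shown leave open whether fluoro, methyl or methoxy in place of chloro on this carbon would raise the number as well. They also leave open whether an amine or a carboxylic acid there would behave differently.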